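Swapping Dimethylamino for Acetyl on the Aryl Tail

This account rests on a few compounds, and the source may have more. Where it says the series, first, only, none or still open, it means among the compounds named here.

Compound 1 `COc1cc(C)cc(-c2c(-c3ccnc(-c4ccc(N(C)C)cc4)c3)cnn2CC#N)c1`: 36%
Compound 2 `COc1cc(C)cc(-c2nn(CC#N)cc2-c2ccnc(-c3ccc(N(C)C)cc3)c2)c1`: 104%

In a functional assay on T47D cells (Homo sapiens) for cytotoxicity, read by sulforhodamine B assay, with a stated time of 48 h, tested at 0.01 uM (on this read-out higher numbers stand for a weaker effect at the one concentration tested and lower numbers for a stronger effect), compound 1 gives 36%, the lowest of the two numbers and thus the stronger effect; compound 2 gives 104%, a gap beyond the usual scatter. Compound 3 `COc1cc(C)cc(-c2c(-c3ccnc(-c4ccc(C(C)=O)cc4)c3)cnn2CC#N)c1` has not yet been measured. It differs from compound 1 by acetyl in place of dimethylamino on an aromatic carbon, on an aromatic carbon of a six-membered aromatic ring of carbon only. Going by the values given here, no measured pair shows this change, so its size is uncertain; a moderate loss is expected, a number 24 percentage points higher from compound 1 to compound 3 (beyond the scatter). Compound 3 is estimated at 60%, within 30% to 100%.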

Compound 3, a percentage reported as activity, at one concentration (the size of the read-out at that concentration, not a potency): 92%
Estimate against measurement, compound 3: 32 percentage points below; low and high end bracket the measured number.
By their numbers in this assay, from the lowest: compound 1; then compound 3; then compound 2.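

In this assay, the group at this place on the aryl tail clearly matters: acetyl in place of dimethylamino gives a large step, a number 56 percentage points higher from compound 1 to compound 3 (beyond the scatter), so the effect at the one concentration tested is much weaker. The two groups match in heavy-atom and hydrogen-bond acceptor counts, so these counts alone do not separate them. Nothing measured here explains the loss. Still open, on these data alone, is whether other groups at this place, such as a primary amine or a morpholine, would keep the effect of compound 1.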